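The source may hold more compounds than are shown below. What is called first, only, known or untested is meant among the compounds shown, and "the series" means these compounds.

Measured compounds:
compound 1 `CC(C)OC(=O)N1CCC(Oc2ncnc3c2CCN3c2ccc(-c3nccs3)cc2F)CC1` — in a functional assay on CHO-K1 cells for agonist activity at Glucose-dependent insulinotropic receptor (Homo sapiens), read by a luciferase reporter, with a stated time of 5 h (a higher number here means that more compound is needed for the effect, a lower number that less compound is needed), compound 1 gives 79.4 nM
compound 2 `CCCCOC(=O)N1CCC(Oc2ncnc3c2CCN3c2ccc(S(C)(=O)=O)cc2F)CC1` — in this assay compound 2 gives 50.1 nM

The two compounds share a core and a piperidine carbamate, and both were run in this assay. Compound 2 sits at the low end of the two numbers, but compound 1 is close by and the gap between them lies within the usual scatter, so no ranking of the two can be read from these values.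

Compound 3 `CC(C)SC(=O)N1CCC(Oc2ncnc3c2CCN3c2ccc(S(C)(=O)=O)cc2F)CC1` is the next compound to be measured in this assay. It differs from compound 2 in one place: isopropylsulfanyl in place of butoxy on a carbonyl carbon. Among the measured compounds shown here, no measured pair in this set shows this kind of exchange, so there is no step to lean on. The change keeps the carbonyl and the ring nitrogen intact and swaps only the group on the other side of the carbonyl carbon. The step from compound 2 to compound 3 is therefore expected to be small, a 1.2-fold higher number from compound 2 to compound 3 (0.08 log units; within the scatter), with no direction that can be called beyond the scatter. Compound 3 is estimated at 60 nM in this assay, within a range from 20 nM to 200 nM.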

Compound 3, half-maximal effective concentration: 10 nM
The estimate for compound 3 lay 6.0-fold (0.78 log units) above the measured number, outside the stated range (below it).
By their numbers in this assay, from the lowest: compound 3; then compounds 2 and 1 (each within the scatter of the next).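

The exchange of butoxy for isopropylsulfanyl on a carbonyl carbon bonded to an amide-type nitrogen in a ring gives a 5.0-fold lower number from compound 2 to compound 3 (0.70 log units; beyond the scatter) in this assay and shows that this position responds to what stands on that carbonyl carbon. Among the compounds shown here, compound 1 and compound 2 differ in more than one place, so they could not show this, whereas compound 2 and compound 3 differ only here and give the first step in this set that lies beyond the scatter. The exchange alters both the atom attached to the carbonyl carbon, oxygen to sulfur, and the carbon group, a butyl chain to a branched isopropyl group, and nothing shown here gives a reason for the step.

The compounds shown do not separate these two alterations, and isopropoxy and butylsulfanyl at the same place would be the groups to tell them apart. From the compounds shown here alone, it also remains open whether isopropylsulfanyl would give a similar step alongside the thiazolyl-bearing aryl group of compound 1, or how longer sulfur-linked chains or an amine in the same place would read.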